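The compounds below may be only part of what the source reports. "The series", "measured", "known", "first", "only" and "open" are said of these compounds alone.

Working notes on the series. Within the data shown here, in a functional assay on L1210 cells (Mus musculus) for antiproliferative activity, read by MTT assay, with a stated time of 2 days (a lower number here means a stronger inhibitor, a higher number a weaker inhibitor), compound 1 (`Cc1ccc(C#Cc2cn(C/C=C\CN3C(=O)c4ccccc4C3=O)c(=O)[nH]c2=O)cc1`) gives 245000 nM and stands as the higher of the two numbers so far, while compound 2 (`CCCCCc1ccc(C#Cc2cn(C/C=C/CN3C(=O)c4ccccc4C3=O)c(=O)[nH]c2=O)cc1`) gives 39000 nM and differs from it in more than one place. Compound 3 (`CCCCC#Cc1cn(C/C=C\CN2C(=O)c3ccccc3C2=O)c(=O)[nH]c1=O`) carries butyl in place of 4-methylphenyl on a triple-bonded carbon. Among the measured compounds shown here, no measured pair isolates this change, so only a modest move towards a lower number is expected, estimated as a 2.0-fold lower number from compound 1 to compound 3 (0.31 log units; beyond the scatter) with wide uncertainty. In this assay compound 3 is expected at 120000 nM within an estimated range of 40000 nM to 350000 nM (not yet measured).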

Compound 3, half-maximal inhibitory concentration: 109000 nM
Compound 3: middle estimate off by 1.1-fold (0.04 log units), on the high side, within the range that was stated.
By their numbers in this assay, from the lowest: compound 2; then compound 3; then compound 1.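

In this assay, the step at this position reads a 2.2-fold lower number from compound 1 to compound 3 (0.35 log units; beyond the scatter), with butyl on the triple-bonded carbon in place of 4-methylphenyl. A six-membered aromatic ring at this place is therefore not needed to keep this level of antiproliferative activity in this pair: the open chain, with fewer heavy atoms, gives the lower number. Nothing at hand explains this step.

Still open, from the compounds shown here alone, is whether a longer chain such as octyl, or a chain ending in an amine, would lower the number further. Also open, going by these compounds, is whether the same change holds with the double-bond geometry of compound 2.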